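The compounds below may be only part of what the source reports. "The series", "measured", "known", "first", "only" and "open" are said of these compounds alone.

In a functional assay on MCF7 cells (Homo sapiens) for inhibition, read by fluorescence, with a stated time of 72 h (on this read-out lower numbers stand for stronger inhibition of growth and higher numbers for weaker inhibition of growth), three compounds of one series have been measured. Compound 1 `CC(C)CCn1cnc2c(Nc3ccc(Cl)cc3)nc(N[C@H]3CC[C@H](N)CC3)nc21` gives 2700 nM. Compound 2 `CC(C)CCn1cnc2c(Nc3cccc(Cl)c3)nc(N[C@H]3CC[C@H](N)CC3)nc21` carries 3-chlorophenyl in place of 4-chlorophenyl on a nitrogen on an aromatic ring and in this assay gives 2100 nM, a step of a 1.3-fold lower number from compound 1 to compound 2 (0.11 log units; within the scatter). Compound 3 `CCCCn1cnc2c(Nc3ccc(Cl)cc3)nc(N[C@H]3CC[C@H](N)CC3)nc21` has a different core, (hydrogen in place of methyl on a saturated chain carbon bound to two saturated chain carbons), and in this assay gives 2100 nM, a step of a 1.3-fold lower number from compound 1 to compound 3 (0.11 log units; within the scatter). Compound 2 and compound 3 thus give the same number, and neither can be set apart from compound 1.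

Compound 4 `CCCCn1cnc2c(Nc3cccc(Cl)c3)nc(N[C@H]3CC[C@H](N)CC3)nc21` is still to be measured. It carries on the core of compound 3 the same change that compound 2 carries on the core of compound 1, (3-chlorophenyl in place of 4-chlorophenyl on a nitrogen on an aromatic ring); the place of the change is the same in both pairs, so this is the same change, seen twice among these four compounds and measured once so far. Compound 4 is expected to show a step of a 1.2-fold lower number from compound 3 to compound 4 (0.09 log units; within the scatter), because in the measured pair this change gave a 1.3-fold lower number from compound 1 to compound 2 (0.11 log units; within the scatter). In this assay compound 4 is therefore estimated at 1700 nM, with the expected range running from 900 nM to 3500 nM.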

Compound 4, concentration for 50% growth inhibition: 2000 nM
Beside the measured number, compound 4's estimate is 1.2-fold (0.07 log units) below it; measured number inside the range.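

In this assay, 3-chlorophenyl in place of 4-chlorophenyl on the core of compound 3 gives a 1.1-fold lower number from compound 3 to compound 4 (0.02 log units; within the scatter), and this step does not differ from the one seen earlier on the core of compound 1: the same change on two cores in this assay, a 1.3-fold lower number (0.11 log units; within the scatter) from compound 1 to compound 2 and a 1.1-fold lower number (0.02 log units; within the scatter) from compound 3 to compound 4, 1.2-fold (0.09 log units) apart, within the scatter of two such steps. Hydrogen in place of methyl on the saturated chain carbon gives a 1.1-fold lower number from compound 2 to compound 4 (0.02 log units; within the scatter), and this step likewise agrees with its earlier counterpart: the same change on two cores in this assay, a 1.3-fold lower number (0.11 log units; within the scatter) from compound 1 to compound 3 and a 1.1-fold lower number (0.02 log units; within the scatter) from compound 2 to compound 4, 1.2-fold (0.09 log units) apart, within the scatter of two such steps. Among these compounds, each change therefore reads the same on both cores, but since all four steps lie within the scatter, this shows only that neither change moved the number measurably on either core, not that a change with a real effect would carry from one core to the other.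

The four compounds leave open whether a step beyond the scatter would carry over in this way. That could be tested with a methoxyphenyl group in place of the chlorophenyl group, or with a longer chain such as hexyl on the core.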